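This account rests on a few compounds, and the source may have more. Where it says the series, first, only, none or still open, it means among the compounds named here.

Measured in a functional assay on MCF7 cells (Homo sapiens) for antiproliferative activity, with a stated time of 5 days; on this read-out higher numbers stand for weaker inhibition and lower numbers for stronger inhibition:
- Compound 1 `CCCCc1ccc2[nH]c(-c3ccc(CC)cc3)c(C=O)c2c1`: 58 nM
- Compound 2 `CCCCc1ccc2[nH]c(-c3ccc(OC)cc3)c(/C=N/NC(=O)c3ccc(Cl)cc3)c2c1`: 220 nM

Compound 2 has the higher of these two numbers, which means weaker inhibition, and its gap to compound 1 lies beyond the usual scatter. Compound 3 `CCCCc1ccc2[nH]c(-c3ccc(OC)cc3)c(/C=N/NC(=O)c3ccc([N+](=O)[O-])cc3)c2c1` differs from compound 2 in one place, with nitro in place of chloro on an aromatic carbon. Within the data shown here, no measured pair shows this change, so no step beyond the scatter is expected in this assay. The estimated step runs a 1.1-fold lower number from compound 2 to compound 3 (0.04 log units; within the scatter). Compound 3 is expected at 200 nM, with an estimated range of 70 nM to 600 nM.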

Compound 3, half-maximal inhibitory concentration: 312 nM
Estimate against measurement, compound 3: 1.6-fold (0.19 log units) below, within the range that was stated.
By their numbers in this assay, from the lowest: compound 1; then compounds 2 and 3 (each within the scatter of the next).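

Replacing 4-chlorophenyl with 4-nitrophenyl gives a 1.4-fold higher number from compound 2 to compound 3 (0.15 log units; within the scatter) in this assay, so this read-out does not separate the two groups, although nitro brings hydrogen-bond acceptors that chloro lacks. Compound 1 and compound 2 differ in more than one place, so they could not show this. Nothing measured here gives a reason for this result. On these data alone, whether an amine or a carboxylic acid at this position would give a similar number remains open, and so does the effect of a longer chain there.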